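Methoxy for ethoxy: a small change in the series

The source may report more compounds than this note shows. Statements on the series, on what has been measured and on what is new or still open speak of the compounds shown alone.

Measured compounds:
compound 1 `CCOc1cccc(S(=O)(=O)Nc2ccc(N3CCN(c4cccc(-c5c(C(=O)NCCCN6CCN(C)CC6)c(C)n(C)c5-c5ccc(Cl)cc5)c4)CC3)cc2)c1` — 1620 nM
compound 2 `Cc1c(C(=O)O)c(-c2cccc(N3CCN(c4ccc(NS(=O)(=O)c5ccc(N[C@H](CCN6CCC(O)CC6)CSc6ccccc6)c(S(=O)(=O)C(F)(F)F)c5)cc4)CC3)c2)c(-c2ccc(Cl)cc2)n1C(C)C` — 4 nM

In an assay for inhibition of Apoptosis regulator Bcl-2 (Homo sapiens), read by fluorescence polarization, with a stated time of 2 h (on this read-out lower numbers stand for stronger inhibition and higher numbers for weaker inhibition), compound 1 gives 1620 nM, the highest of the two numbers shown. Compound 2 gives 4 nM in this assay, a far lower number; the two structures differ in many places, so the pair says nothing about any single change.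

Compound 3 `COc1cccc(S(=O)(=O)Nc2ccc(N3CCN(c4cccc(-c5c(C(=O)NCCCN6CCN(C)CC6)c(C)n(C)c5-c5ccc(Cl)cc5)c4)CC3)cc2)c1` differs from compound 1 by hydrogen in place of methyl on a saturated chain carbon bound to an oxygen on an aromatic ring. Within the data shown here, no measured pair shows this change. Compound 3 is expected to sit close to compound 1, with a step of a 1.1-fold higher number from compound 1 to compound 3 (0.05 log units; within the scatter) not beyond the scatter. Compound 3 is estimated at 1800 nM, range 700 nM to 4500 nM.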

Compound 3, half-maximal inhibitory concentration: 802 nM
Compound 3: middle estimate off by 2.2-fold (0.35 log units), on the high side; measured number inside the range.
By their numbers in this assay, from the lowest: compound 2; then compound 3; then compound 1.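

Among these compounds, the change from ethoxy to methoxy gives the first single-place reading in this assay and it is a 2.0-fold lower number from compound 1 to compound 3 (0.31 log units; beyond the scatter) and so modest. This place on the aromatic ring therefore responds to the loss of one carbon, with the shorter chain giving the lower number. No measurement here accounts for the step.

Open, from the compounds shown here alone, is how a propoxy chain, a hydroxy group or a bare hydrogen in place of the whole alkoxy group would compare with these two. One step also leaves open whether this change reads the same with another amide chain on the shared core.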